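This account rests on a few compounds, and the source may have more. Where it says the series, first, only, none or still open, it means among the compounds named here.

Of the compounds shown here, three have been measured in an ADME assay (liver) for pharmacokinetics, with Liver microsome (Homo sapiens) as the target, using microsomes; on this read-out higher numbers stand for a longer-lived compound and lower numbers for a shorter-lived compound.
Compound 1 `CCOc1cc(NC(=O)C2(NC(=O)c3ccc4c(C5CCCC5)c(-c5ncc(Cl)cn5)n(C)c4c3)CCC2)ccc1/C=C/C(=O)OCOP(=O)(O)OC(C)(C)C`: 1.48 h
Compound 2 `CCOC(=O)/C=C/c1ccc(NC(=O)C2(NC(=O)c3ccc4c(C5CCCC5)c(-c5ncc(Cl)cn5)n(C)c4c3)CCC2)cc1OCC`: a limit of the assay, > 5 h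
Compound 3 `CCOc1cc(NC(=O)C2(NC(=O)c3ccc4c(C5CCCC5)c(-c5ncc(Cl)cn5)n(C)c4c3)CCC2)ccc1/C=C/C(=O)OCC(N)=O`: 0.983 h

Of the two plain numbers, compound 3 holds the smaller, yet the step of a 1.5-fold lower number from compound 1 to compound 3 (0.18 log units; within the scatter). Compound 4 `CCOc1cc(NC(=O)C2(NC(=O)c3ccc4c(C5CCCC5)c(-c5ncc(Cl)cn5)n(C)c4c3)CCC2)ccc1/C=C/C(=O)OCC(=O)N(C)C(C)C` differs from compound 3 by isopropyl(methyl)amino in place of amino on a carbonyl carbon. For the measured compounds named here, two measured steps touch the same region: an at least 3.3-fold higher number from compound 1 to compound 2 (0.52 log units; beyond the scatter) and an at least 5.0-fold lower number from compound 2 to compound 3 (0.70 log units; beyond the scatter), both beyond the scatter, the second being the one that set compound 3 apart. The change to compound 4 sits one bond further out on that carbamoyl, so a modest step upward is expected, a 1.6-fold higher number from compound 3 to compound 4 (0.21 log units; within the scatter). Compound 4 is therefore estimated at 1.6 h, with a range from 0.6 h to 4.5 h.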

Compound 4, half-life: 0.65 h
Estimate against measurement, compound 4: 2.5-fold (0.39 log units) above, and the stated range covers the measured number.
By their numbers in this assay, from the lowest: compounds 4, 3 and 1 (each within the scatter of the next, the first and the last beyond it). At a limit, above all of these: compound 2.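

Isopropyl(methyl)amino in place of amino on a carbonyl carbon gives a 1.5-fold lower number from compound 3 to compound 4 (0.18 log units; within the scatter) in this assay and so leaves compound 3 and compound 4 unresolved. Both a 2.3-fold lower number from compound 1 to compound 4 (0.36 log units; beyond the scatter) and an at least 7.6-fold lower number from compound 2 to compound 4 (0.88 log units; beyond the scatter) lie beyond the scatter, whereas the step from compound 1 to compound 3 did not. Compound 2 gives a limit, not a number: the limit of > 5 h in this assay, at which 1 of the 4 values shown sits.

Still open, as far as these compounds go, is how a carboxylic acid or a morpholine amide would read on this carbonyl carbon. Also open, from the compounds shown here alone, is what separates these esters from compound 2.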